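Two Measured Analogues and One Ring Exchange to Predict

The compounds below may be only part of what the source reports. "The series", "measured", "known", "first", "only" and "open" are said of these compounds alone.

compound 1 `CCOC(=O)C1=C(Nc2ccccc2)S/C(=C\c2ccc(OC)cc2)C1=O`: 32.9%
compound 2 `CCOC(=O)C1=C(Nc2ccccc2Br)S/C(=C\c2ccc[nH]2)C1=O`: 62.7%

In a functional assay on JAR cells (Homo sapiens) for inhibition, read by MTT assay, with a stated time of 72 h, tested at 10 uM (a higher number here means more inhibition at the concentration tested (going by the name of the read-out), a lower number less inhibition), compound 1 gives 32.9%, the lower of the two measured values; compound 2 gives 62.7%, and the gap between them lies beyond the usual scatter. Going by the values given here, these two compounds differ in more than one place, so no single step connects them. Compound 3 `CCOC(=O)C1=C(Nc2ccccc2)S/C(=C\c2cc3cccnc3[nH]2)C1=O` differs from compound 1 in one place: a group of 9 heavy atoms (7 carbon, 2 nitrogen; one five-membered aromatic ring with 1 hetero atom, one six-membered aromatic ring with 1 hetero atom) in place of a group of 8 heavy atoms (7 carbon, 1 oxygen; one six-membered aromatic ring of carbon only), on a double-bonded chain carbon bound to a double-bonded ring carbon. Among the compounds with values here, no measured step covers this exchange, so a modest rise in inhibition is expected, about a number 12.1 percentage points higher from compound 1 to compound 3 (beyond the scatter), with a fall not excluded. Compound 3 is therefore estimated at 45%, with a range from 25% to 70%.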

Compound 3, a percentage reported as inhibition, at one concentration (the size of the read-out at that concentration, not a potency): 54.3%
Beside the measured number, compound 3's estimate is 9.3 percentage points below it, and the stated range covers the measured number.
By their numbers in this assay, from the lowest: compound 1; then compounds 3 and 2 (each within the scatter of the next).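

In this assay, this place on the double-bonded chain carbon proves sensitive to what it carries: the exchange of 4-methoxyphenyl for the two-ring group gives a number 21.4 percentage points higher from compound 1 to compound 3 (beyond the scatter). So 4-methoxyphenyl is not needed there for inhibition in these cells. No available evidence bears on the reason for this rise.

The exchange alters the rings, the atoms and the hydrogen-bond donors together, so the step cannot show which of these matters. An indole group, with carbon in place of the six-membered ring's nitrogen, would begin to separate them.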